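The source may report more compounds than this note shows. Statements on the series, on what has been measured and on what is new or still open speak of the compounds shown alone.

Measured so far:
compound 1 `O=C(CSc1ncccn1)N/N=c1/scc(-c2ccc(Cl)cc2)n1-c1ccccc1`: in a functional assay on C6 cells (Rattus norvegicus) for cytotoxicity, read by MTT assay, with a stated time of 24 h, tested at 12 ug/mL (a lower number here means a stronger effect, a higher number a weaker effect of the compound at the concentration tested), compound 1 gives 91.6%
compound 2 `Cc1ccc(-c2cs/c(=N/NC(=O)CSc3ncccn3)n2-c2ccccc2)cc1`: in this assay compound 2 gives 83%

Compound 2 stands at the lowest of the two numbers; its nearest neighbour is compound 1, and the step is a number 8.6 percentage points lower from compound 1 to compound 2 (within the scatter), which lies within the usual scatter. Compound 3 `COc1ccc(-c2cs/c(=N/NC(=O)CSc3ncccn3)n2-c2ccccc2)cc1` is the next member; it differs from compound 2 by methoxy in place of methyl on an aromatic carbon.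

Going by the values given here, only one measured step bears on this change: the one from compound 1 to compound 2, which also swaps a single substituent at the same position of the same ring and came out as a number 8.6 percentage points lower from compound 1 to compound 2 (within the scatter), within the scatter. Among the compounds with values here, with one small step as the only guide, no movement beyond the scatter is expected in this assay for compound 3. The estimated step is a number 2 percentage points higher from compound 2 to compound 3 (within the scatter). Compound 3 is therefore expected to read about 85%, within a range of 70% to 98%.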

Compound 3, a percentage reported as activity, at one concentration (the size of the read-out at that concentration, not a potency): 78.4%
Estimate against measurement, compound 3: 6.6 percentage points above, and the stated range covers the measured number.
By their numbers in this assay, from the lowest: compounds 3, 2 and 1 (each within the scatter of the next, the first and the last beyond it).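

In this assay, going by these compounds alone, the step from chloro to methoxy reads a number 13.2 percentage points lower from compound 1 to compound 3 (beyond the scatter) and is the first step beyond the scatter at this place, on an aromatic carbon para to a large group, so the substituent here can change the read-out at the tested concentration. The replacement of methyl by methoxy reads a number 4.6 percentage points lower from compound 2 to compound 3 (within the scatter) and leaves compound 2 unresolved from compound 3, just as compound 2 is unresolved from compound 1, so the only gap that can be read is the one between the chloro and methoxy compounds. Nothing available accounts for that gap.

As far as these compounds go, whether an amine or a carboxylic acid at this place would move the read-out further remains open. Also open, from the compounds shown here alone, is whether the gap between chloro and methoxy would persist with the same groups elsewhere on that ring.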